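Swapping halogens on the sulfonyl aryl of compound 1

The source may hold more compounds than are shown below. What is called first, only, known or untested is meant among the compounds shown, and "the series" means these compounds.

Measured compounds:
- compound 1, `CC1CCN(c2c(S(=O)(=O)c3cc(F)cc(F)c3)cnc3cc(Cl)ccc23)CC1`: 94%
- compound 2, `O=S(=O)(c1cccc(F)c1)c1cnc2cc(Cl)ccc2c1N1CCC(CO)CC1`: 71%
- compound 3, `CC1CCN(c2c(S(=O)(=O)c3cc(F)cc(F)c3)cnc3cc(F)ccc23)CC1`: 77%

In an assay on isolated protein for displacement of a labelled ligand from metabotropic glutamate receptor 5 (Homo sapiens), with a stated time of 60 min, tested at 1 uM (on this read-out lower numbers stand for less inhibition and higher numbers for more inhibition at the one concentration tested (going by the name of the read-out)), compound 1 stands highest of the three numbers. Its nearest neighbour is compound 3, and the step of a number 17 percentage points lower from compound 1 to compound 3 (beyond the scatter) lies beyond the scatter. For the measured compounds named here, compound 2 sits furthest down, and no single-change step connects it to compound 1; its value simply stands lower.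

The unmeasured compound 4, `CC1CCN(c2c(S(=O)(=O)c3cc(Cl)cc(Cl)c3)cnc3cc(Cl)ccc23)CC1`, differs from compound 1 in one place: 3,5-dichlorophenyl in place of 3,5-difluorophenyl on a sulfonyl sulfur. Going by the values given here, the only measured step, from compound 1 to compound 3, swaps chloro for fluoro at a different place on the core and lowers the number; read the other way, chloro in place of fluoro raised it there. Nothing measured bears directly on the sulfonyl aryl. Because compound 1 already gives 94%, little room remains upward, so the expected step of a number 4 percentage points lower from compound 1 to compound 4 (within the scatter) is within the scatter or slightly downward. Compound 4 is therefore estimated at 90%, with a range of 75% to 99%.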

Compound 4, a percentage reported as inhibition, at one concentration (the size of the read-out at that concentration, not a potency): 93%
Compound 4: middle estimate off by 3 percentage points, on the low side; the measured number falls inside the stated range.
By their numbers in this assay, from the lowest: compounds 2 and 3 (each within the scatter of the next); then compounds 4 and 1 (each within the scatter of the next).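

In this assay, for the compounds shown here, the first measured change on the sulfonyl aryl, 3,5-dichlorophenyl in place of 3,5-difluorophenyl on a sulfonyl sulfur, gives a number 1 percentage points lower from compound 1 to compound 4 (within the scatter). Going by these compounds alone, at this place, then, the two halogen pairs cannot be told apart by this read-out, whereas the single halogen swap on the shared core gave a number 17 percentage points lower from compound 1 to compound 3 (beyond the scatter), so a halogen exchange does not count the same at every place on compound 1. Nothing at hand explains why the two places differ.

Compound 1 and compound 4 both stand near the top of a percentage scale at a single concentration, so measurements at further concentrations might still separate them. Also open, on these data alone, is how the number would respond to a sulfonyl aryl carrying something other than halogen, such as a methoxy group, a nitrile or an amine.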